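Methoxy-to-hydroxy step carried onto the difluorobenzyl amide

The compounds below may be only part of what the source reports. "The series", "measured", "known", "first", "only" and "open" are said of these compounds alone.

Compound 1 `COc1ccc2c(=O)c(/C=C/C(=O)Nc3ccccc3)coc2c1` gives 51000 nM in a functional assay on A549 cells (Homo sapiens) for inhibition, read by MTT assay, with a stated time of 48 h; a higher number here means a weaker inhibitor, a lower number a stronger inhibitor. Compound 2 `O=C(/C=C/c1coc2cc(O)ccc2c1=O)Nc1ccccc1` differs from compound 1 by hydrogen in place of methyl on an oxygen on an aromatic ring; in this assay compound 2 gives 24400 nM, a step of a 2.1-fold lower number from compound 1 to compound 2 (0.32 log units; beyond the scatter). Compound 3 `COc1ccc2c(=O)c(/C=C/C(=O)NCc3ccc(F)cc3F)coc2c1` differs from compound 1 by 2,4-difluorobenzyl in place of phenyl on an amide-type nitrogen; in this assay compound 3 gives 13300 nM, a step of a 3.8-fold lower number from compound 1 to compound 3 (0.58 log units; beyond the scatter). Compound 4 `O=C(/C=C/c1coc2cc(O)ccc2c1=O)NCc1ccc(F)cc1F` is not yet measured; it differs from compound 3 by hydrogen in place of methyl on an oxygen on an aromatic ring, the same change as from compound 1 to compound 2, made at a place described in the same words, while the two cores differ as noted for compound 3 against compound 1. Because the earlier step of a 2.1-fold lower number from compound 1 to compound 2 (0.32 log units; beyond the scatter) was modest, a step of similar size is expected, a 2.0-fold lower number from compound 3 to compound 4 (0.31 log units; beyond the scatter), resting on that single precedent. Compound 4 is expected to give about 6500 nM in this assay, between 2800 nM and 15000 nM.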

Compound 4, half-maximal inhibitory concentration: 6610 nM
Estimate against measurement, compound 4: 1.0-fold (0.01 log units) below; the range from low to high includes it.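

In this assay the methoxy to hydroxy change on the difluorobenzyl amide gives a 2.0-fold lower number from compound 3 to compound 4 (0.30 log units; within the scatter), a step that on its own stays within the scatter. Set against the same change on the phenyl amide, the step carries across the two cores with no difference in size that can be told apart: the same change on two cores in this assay, a 2.1-fold lower number (0.32 log units; beyond the scatter) from compound 1 to compound 2 and a 2.0-fold lower number (0.30 log units; within the scatter) from compound 3 to compound 4, 1.0-fold (0.02 log units) apart, within the scatter of two such steps. This rests on two pairs in a single assay, so it does not show that the step holds on other amides or in other assays, and it gives no reason for the step.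

Still open, going by these compounds, is whether the step persists with a longer chain or a carboxylic acid on the amide nitrogen. Also open, on these data alone, is how an amine or an ethoxy group compares with the hydroxy at that place on the ring.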